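The source may hold more compounds than are shown below. What is called first, only, known or untested is meant among the compounds shown, and "the series" means these compounds.

Measured so far:
- compound 1 `O=C(/C=C/c1ccc(OCCCCCCO[N+](=O)[O-])c(O)c1)OCCCCCCO[N+](=O)[O-]`; in a functional assay on M14 cells (Homo sapiens) for cytotoxicity, read by resazurin assay, with a stated time of 72 h (on this read-out lower numbers stand for stronger inhibition and higher numbers for weaker inhibition), compound 1 gives > 50000 nM, which is a limit of the assay and not a number.
- compound 2 `COc1cc(/C=C/C(=O)Oc2cccc(OCc3c(-c4ccccc4)no[n+]3[O-])c2)ccc1O`; in this assay compound 2 gives > 50000 nM, again a limit of the assay.
- compound 3 `COc1cc(/C=C/C(=O)OCCOc2no[n+]([O-])c2S(=O)(=O)c2ccccc2)ccc1O`; in this assay compound 3 gives > 50000 nM, also a limit of the assay.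

Compound 1 therefore stands nowhere in particular on the numbers shown: its own value is a limit, and the two other values are limits as well, so no order among the three compounds can be read and no compound can be called stronger or weaker than another. The whole measured picture is summed up by the limit of > 50000 nM in this assay, at which 3 of the 3 values shown sit. Among the compounds with values here, no pair of measured compounds differs in a single place, so no measured step is available to lean on.

Compound 4 `COc1cc(/C=C/C(=O)OCCCCCCO[N+](=O)[O-])ccc1OCCCCCCO[N+](=O)[O-]` is not yet measured. Against compound 1 the change is methyl in place of hydrogen on an oxygen on an aromatic ring. Because every measured value sits at the limit of > 50000 nM in this assay, at which 3 of the 3 values shown sit, the expectation for the step in this assay is none beyond the scatter, in no particular direction, and compound 4 is expected to come back as a limit too. For compound 4 the estimated value is 60000 nM, with an expected range from 30000 nM to 200000 nM. The expected step is a step that the limit leaves unreadable from compound 1 to compound 4.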

Compound 4, half-maximal inhibitory concentration: > 50000 nM
Compound 4 gave a limit, no number; the forecaster's own chance of this, stated with the estimate: 85%; the middle value lies beyond the limit too.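

Compound 1 and compound 4 both stand at a limit of the assay in this assay, not at a number, so the step between them from hydroxy to methoxy cannot be read: the limit of > 50000 nM in this assay, at which 4 of the 4 values shown sit.

The compounds shown leave open whether any member of this series gives a measurable value in this assay and, with that, how large this step is.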